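Amide to urea step on the shared core, compound 4

This account rests on a few compounds, and the source may have more. Where it says the series, first, only, none or still open, it means among the compounds named here.

Measured compounds in a functional assay on PC-3 cells (Homo sapiens) for inhibition, read by sulforhodamine B assay, with a stated time of 48 h; a lower number here means a stronger inhibitor of growth, a higher number a weaker inhibitor of growth:
compound 1 `COc1cc(-c2nn(-c3cccc(NC(=O)c4cccc(C(F)(F)F)c4)c3)cc2-c2ccncc2)ccc1Cl`: 1230 nM
compound 2 `COc1cc(-c2nn(-c3cccc(NC(=O)Nc4cccc(C(F)(F)F)c4)c3)cc2-c2ccncc2)ccc1Cl`: 372 nM
compound 3 `COc1cc(-c2nn(-c3cccc(NC(=O)c4ccc(Cl)c(C(F)(F)F)c4)c3)cc2-c2ccncc2)ccc1Cl`: 1290 nM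

Compound 3 gives the highest of the three numbers. Its nearest neighbour is compound 1, where a 1.0-fold higher number from compound 1 to compound 3 (0.02 log units; within the scatter), so the two cannot be told apart here. Its furthest neighbour is compound 2, where a 3.5-fold higher number from compound 2 to compound 3 (0.54 log units; beyond the scatter). Compound 4 `COc1cc(-c2nn(-c3cccc(NC(=O)Nc4ccc(Cl)c(C(F)(F)F)c4)c3)cc2-c2ccncc2)ccc1Cl` is not yet measured. Relative to compound 3 the change is (4-chloro-3-(trifluoromethyl)phenyl)amino in place of 4-chloro-3-(trifluoromethyl)phenyl on a carbonyl carbon. Among the compounds with values here, the one measured step that matches this change in kind is the one from compound 1 to compound 2, where a 3.3-fold lower number from compound 1 to compound 2 (0.52 log units; beyond the scatter); that step was made on the pair without the chloro, and the chloro itself left the number unchanged, as a 1.0-fold higher number from compound 1 to compound 3 (0.02 log units; within the scatter) shows. The expectation for compound 4 is therefore a step of the same kind and size, a 3.2-fold lower number from compound 3 to compound 4 (0.51 log units; beyond the scatter), toward a lower number. Compound 4 is estimated at 400 nM in this assay, with a range of 200 nM to 800 nM.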

Compound 4, concentration for 50% growth inhibition: 690 nM
Compound 4: the middle estimate sits 1.7-fold (0.24 log units) below what was measured, and the stated range covers the measured number.
By their numbers in this assay, from the lowest: compounds 2, 4, 1 and 3 (each within the scatter of the next, the first and the last beyond it).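

In this assay, the step from amide to urea on the chloro-bearing pair gives a 1.9-fold lower number from compound 3 to compound 4 (0.27 log units; within the scatter), so the step beyond the scatter seen without the chloro (a 3.3-fold lower number from compound 1 to compound 2 (0.52 log units; beyond the scatter)) does not carry over to this pair at that size. Making both changes at once on compound 1 gives a 1.8-fold lower number from compound 1 to compound 4 (0.25 log units; within the scatter), which also leaves the two compounds indistinguishable. On the urea, the chloro gives a 1.9-fold higher number from compound 2 to compound 4 (0.27 log units; within the scatter), and the chloro step reads alike on the amide and urea cores: the same change on two cores in this assay, a 1.0-fold higher number (0.02 log units; within the scatter) from compound 1 to compound 3 and a 1.9-fold higher number (0.27 log units; within the scatter) from compound 2 to compound 4, 1.8-fold (0.25 log units) apart, within the scatter of two such steps.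

Only the amide and urea linkers and two aryl patterns are covered, so the reading of the carbonyl position rests on very few pairs. Still open, as far as these compounds go, is how the number responds to a methyl group on the urea nitrogen, or to a piperazine in place of the chloro.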